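The source may hold more compounds than are shown below. What is called first, only, known or untested is meant among the compounds shown, and "the series" means these compounds.

In a functional assay on HeLa cells (Homo sapiens) for cytotoxicity, read by XTT assay, with a stated time of 72 h (on this read-out higher numbers stand for weaker inhibition and lower numbers for stronger inhibition), compound 1 `CC(=O)c1c(O)cc2c(c1O)CCC(C)(C)O2` gives > 100000 nM, which is a limit of the assay and not a number. For the measured compounds named here, compound 2 `C=C1CC[C@H]2C(C)(C)CCC[C@]2(C)[C@H]1CC/C(C)=C/Cc1c(O)cc(O)c2c(=O)c(O)c(-c3ccc(O)cc3)oc12` gives 30000 nM, the only true number so far. Compound 3 `C=C1CC[C@H]2C(C)(C)CCC[C@]2(C)[C@H]1CC/C(C)=C/COc1cc(O)c2c(=O)c(OC/C=C(\C)CC[C@H]3C(=C)CC[C@H]4C(C)(C)CCC[C@]34C)c(-c3ccc(OC)cc3)oc2c1` gives > 100000 nM, which is also a limit. As far as these compounds go, compound 3 thus stands at the limit of > 100000 nM in this assay, at which 2 of the 3 values shown sit, and its real value is unknown.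

Compound 4 `C=C1CC[C@H]2C(C)(C)CCC[C@]2(C)[C@H]1CC/C(C)=C/COc1cc(O)c2c(=O)c(OC/C=C(\C)CC[C@H]3C(=C)CC[C@H]4C(C)(C)CCC[C@]34C)c(-c3ccc(O)cc3)oc2c1` differs from compound 3 by hydrogen in place of methyl on an oxygen on an aromatic ring, turning 4-methoxyphenyl into 4-hydroxyphenyl. Going by the values given here, no measured pair isolates this change, so the only guide is loose. Compound 2 also carries the 4-hydroxyphenyl group and gives 30000 nM, but it differs from compound 4 elsewhere as well.

A small move toward stronger inhibition is expected in this assay, and the assay may again report only a limit. The estimated step runs an at least 1.4-fold lower number from compound 3 to compound 4 (0.15 log units; that floor lies within the scatter). The expected value for compound 4 is 70000 nM, with an estimated range of 25000 nM to 100000 nM.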

Compound 4, half-maximal inhibitory concentration: > 100000 nM
Compound 4: only a limit was reported; the forecaster's own chance of this, stated with the estimate: 55%; middle value at least 1.4-fold (0.15 log units) away from the limit.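

In this assay compound 3 and compound 4 both end at a limit and not a number, so no step can be read for methoxy to hydroxy: the limit of > 100000 nM in this assay, at which 3 of the 4 values shown sit.

The compounds shown leave open whether 4-hydroxyphenyl in place of 4-methoxyphenyl changes inhibition at all.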